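Swapping one amide group on a highly soluble compound

A few compounds are considered here, and "the series" means these few. Any claim that something is new, unique, unknown or untested is made for them only; others in the source may bear on it.

Compound 1 `CNC(=O)c1cc(C(=O)NCCO)n([C@@H](C)c2ccccc2)n1` is the starting point here. In a physicochemical assay for solubility (on this read-out lower numbers stand for lower solubility and higher numbers for higher solubility), compound 1 gives >= 139 ug/mL as its result, and this is a limit, not an exact number. Compound 2 `CNC(=O)c1cc(C(=O)N[C@H]2CC[C@H](O)CC2)c([C@@H](C)c2ccccc2)o1` gives >= 184 ug/mL in this assay as its result, and this too is a limit. So neither compound yet offers an exact number to work from, and no measured pair shows what a change of this kind does.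

Compound 3 `CNC(=O)c1cc(C(=O)N[C@H]2[C@@H]3C[C@@H](O)C[C@@H]32)n([C@@H](C)c2ccccc2)n1` keeps the core of compound 1 and alters one group, with a group of 7 heavy atoms (6 carbon, 1 oxygen; one three-membered non-aromatic ring of carbon only, one five-membered non-aromatic ring of carbon only) in place of a group of 3 heavy atoms (2 carbon, 1 oxygen; no ring), on an amide-type nitrogen as the whole difference. A modest downward move is expected in this assay, and it may stay within the usual scatter. The estimated change an at least 1.0-fold lower number from compound 1 to compound 3 (0.02 log units; that floor lies within the scatter) is only a rough expectation. For compound 3 the estimated solubility is 130 ug/mL as a central value, with an expected range from 50 ug/mL up to 200 ug/mL in this measurement.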

Compound 3, solubility: >= 291 ug/mL
Compound 3: a limit, no number; the forecaster's own chance of this, stated with the estimate: 50%; middle value at least 2.2-fold (0.34 log units) from the limit.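

In this assay compound 1 gives >= 139 ug/mL, which is a limit. Compound 3 gives >= 291 ug/mL, also a limit. These two limits leave the step from compound 1 to compound 3 unreadable. The compounds shown leave open how far, and in which direction, this amide group swap moves the result.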